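Triazole Attachment Isomer in a Kinase Inhibitor Series

The compounds below may be only part of what the source reports. "The series", "measured", "known", "first", "only" and "open" are said of these compounds alone.

Measured compounds:
compound 1, `N#Cc1cnc(NCc2cnccc2C(F)(F)F)cc1N[C@H]1CC[C@@H](O)CC1`: 100 nM
compound 2, `N#Cc1cnc(NCc2cnccc2C(F)(F)F)cc1N[C@H]1CC[C@@H](c2nc[nH]n2)CC1`: 34 nM

In an assay on isolated protein for inhibition of protein kinase C theta type (Homo sapiens), read by TR-FRET, with a stated time of 2 h (a lower number here means a stronger inhibitor, a higher number a weaker inhibitor), compound 2 has the lowest of the two numbers on hand. Within the data shown here, its only neighbour is compound 1, and the step of a 2.9-fold lower number from compound 1 to compound 2 (0.47 log units; beyond the scatter) lies beyond the scatter, so compound 2 is the stronger inhibitor of the pair.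

Compound 3, `N#Cc1cnc(NCc2cnccc2C(F)(F)F)cc1N[C@H]1CC[C@@H](n2cncn2)CC1`, keeps every atom of compound 2 and changes only the way the five-membered ring is joined: 1H-1,2,4-triazol-1-yl in place of 1H-1,2,4-triazol-3-yl on a saturated ring carbon. Among the measured compounds shown here, the single measured step, from compound 1 to compound 2, concerns a different exchange, hydroxy for the triazolyl ring, and says nothing about which ring atom of the triazole carries the attachment. For the measured compounds named here, no step on hand therefore bears directly on the move from compound 2 to compound 3.

With both isomers keeping the same ring and the same overall shape, compound 3 is expected to stay close to compound 2 in this assay, with the step of a 1.6-fold higher number from compound 2 to compound 3 (0.21 log units; within the scatter) expected to fall within or only just beyond the scatter. Compound 3 is estimated at 55 nM, within a range of 20 nM to 160 nM.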

Compound 3, half-maximal inhibitory concentration: 100 nM
Compound 3: middle estimate off by 1.8-fold (0.26 log units), on the low side; the measured number falls inside the stated range.
By their numbers in this assay, from the lowest: compound 2; then compounds 1 and 3 (each within the scatter of the next).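

In this assay, the way the triazole is joined to the saturated ring carbon matters: a 2.9-fold higher number from compound 2 to compound 3 (0.47 log units; beyond the scatter), although the two groups have the same atoms. The advantage of compound 2 over the hydroxy compound, a 2.9-fold lower number from compound 1 to compound 2 (0.47 log units; beyond the scatter), therefore belongs to the 1H-1,2,4-triazol-3-yl group and not to every 1,2,4-triazolyl group, since the other attachment shows no change at the digits printed from compound 1 to compound 3 (within the scatter). The 1H-1,2,4-triazol-3-yl group counts 1 hydrogen-bond donor and 2 hydrogen-bond acceptors, and the 1H-1,2,4-triazol-1-yl group counts 0 donors and 3 acceptors, but nothing available explains why the two attachments differ in this way.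

The compounds shown leave open whether the difference between the isomers follows the donor count or some other feature of the attachment, a question that a tetrazolyl ring or an imidazolyl ring on the same carbon could help to test. They also leave open how a primary amine or a carboxylic acid at this position would compare with the hydroxy group and the two triazolyl groups.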